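Methoxy in Place of Methyl on a Thiazolidinone Series

The compounds below may be only part of what the source reports. "The series", "measured", "known", "first", "only" and "open" are said of these compounds alone.

Of the compounds shown here, three of a shared core have been tested in a functional assay on HOS cells (Homo sapiens) for inhibition, read by CCK-8 assay, with a stated time of 72 h, tested at 1 uM; a lower number here means less inhibition, a higher number more inhibition at the concentration tested (going by the name of the read-out). Compound 1 `COc1ccccc1N1C(=O)C(C)SC1c1cccc(C(=O)NCCCCc2ccccc2)c1` gives 82%. Compound 2 `COc1ccccc1N1C(=O)CSC1c1cc(F)cc(C(=O)O)c1` gives 8%. Compound 3 `COc1ccc(C)cc1N1C(=O)CSC1c1cccc(C(=O)NCCCCc2ccccc2)c1` gives 42%, which puts it second of the three: its number lies well above that of compound 2 and well below that of compound 1, both gaps beyond the usual scatter. The three compounds differ from one another in several places at once, so no single change can be tied to any of these gaps.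

Compound 4 `COc1ccc(OC)c(N2C(=O)CSC2c2cccc(C(=O)NCCCCc3ccccc3)c2)c1` is not yet measured. It differs from compound 3 in one place: methoxy in place of methyl on an aromatic carbon. Within the data shown here, no measured pair shows this change on its own, so nothing from the numbers so far speaks for a large shift in either direction. The step from compound 3 to compound 4 is therefore expected to be small, a number 2 percentage points lower from compound 3 to compound 4 (within the scatter), most likely within the scatter. Compound 4 is accordingly estimated at 40%, with a range from 15% to 68% in this assay.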

Compound 4, a percentage reported as inhibition, at one concentration (the size of the read-out at that concentration, not a potency): 5%
For compound 4 the middle estimate is 35 percentage points above the measured one; measured number below the stated range.
By their numbers in this assay, from the lowest: compounds 4 and 2 (each within the scatter of the next); then compound 3; then compound 1.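

Changing 2-methoxy-5-methylphenyl to 2,5-dimethoxyphenyl gives a number 37 percentage points lower from compound 3 to compound 4 (beyond the scatter) in this assay and so shows that this position, para to a methoxy group and meta to a large group, is sensitive to what sits on it. Among these compounds, this is the first pair here that differs in one place only, and it shows that replacing methyl with methoxy, which brings in one oxygen and one hydrogen-bond acceptor, is enough by itself to move the reading beyond the scatter. Nothing available explains why the number falls.

On these data alone, it remains open whether losing the methyl or gaining the oxygen matters more, a question that a plain hydrogen, a chlorine or a longer chain such as ethoxy at this position could help settle. As far as these compounds go, it is also open whether the same swap would act alike on the core of compound 1.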